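Allyloxy series: chloro added to compound 1

This account rests on a few compounds, and the source may have more. Where it says the series, first, only, none or still open, it means among the compounds named here.

Measured in a functional assay on PC-3 cells (Homo sapiens) for cytotoxicity, read by sulforhodamine B assay, with a stated time of 48 h; a lower number here means a stronger inhibitor, a higher number a weaker inhibitor:
Compound 1 `C=CCOc1c(Cl)cccc1C(=O)c1cccnc1` — > 100000 nM, a limit of the assay and not a number.
Compound 2 `O=C(c1cccnc1)c1cccc(Cl)c1O` — 31500 nM.
Compound 3 `Cc1ccc(O)c(C(=O)c2cccnc2)c1` — 10000 nM.

Compound 1 stands at the limit of > 100000 nM in this assay, at which 1 of the 3 values shown sits; its value is a limit only, so no number is known for it. Compound 4 `C=CCOc1c(Cl)cc(Cl)cc1C(=O)c1cccnc1` differs from compound 1 by chloro in place of hydrogen on an aromatic carbon. Among the measured compounds shown here, the one measured step, an at least 3.1-fold lower number from compound 1 to compound 2 (0.50 log units; beyond the scatter), concerns hydrogen in place of allyl on an oxygen and says nothing about a chloro entering; no measured step bears on the change to compound 4. With no evidence for a shift in either direction, no step beyond the scatter is expected, and compound 4 is estimated to remain at the limit, a step that the limit leaves unreadable from compound 1 to compound 4. Compound 4 is expected near 150000 nM, in the range 40000 nM to 600000 nM.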

Compound 4, half-maximal inhibitory concentration: 96000 nM
Estimate against measurement, compound 4: 1.6-fold (0.19 log units) above, and the stated range covers the measured number.
By their numbers in this assay, from the lowest: compound 3; then compound 2; then compound 4. At a limit, above all of these: compound 1.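

In this assay, with chloro entering para to an allyloxy group, compound 4 reads 96000 nM, so this position now has a measured number in the allyloxy series. Compound 1 has > 100000 nM, a limit of the assay and not a number. The change reads only as an at least 1.0-fold lower number from compound 1 to compound 4 (0.01 log units; that floor lies within the scatter), and its true size stays unreadable because compound 1 sits at a limit: the limit of > 100000 nM in this assay, at which 1 of the 4 values shown sits.

On these data alone, whether an amine or a carboxylic acid at this position would move the number remains open. Also open, as far as these compounds go, is what this chloro does when hydrogen replaces allyl on the oxygen.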